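Furan Isomers on a Shared Core: Compound 2 to Compound 4

A few compounds are considered here, and "the series" means these few. Any claim that something is new, unique, unknown or untested is made for them only; others in the source may bear on it.

Of the compounds shown here, three have been measured in a functional assay on HL-60 cells (Homo sapiens) for antiproliferative activity, read by XTT assay, with a stated time of 72 h; on this read-out higher numbers stand for weaker inhibition and lower numbers for stronger inhibition. Compound 1 `Nc1nc(N)c2c(-c3cc4ccccc4o3)cn([C@@H]3O[C@H](CO)[C@@H](O)[C@H]3O)c2n1` gives > 15000 nM, a limit of the assay rather than a number. Compound 2 `Nc1nc(N)c2c(-c3ccoc3)cn([C@@H]3O[C@H](CO)[C@@H](O)[C@H]3O)c2n1` gives > 20000 nM, which is also a limit. Compound 3 `Cc1nc(N)c2c(-c3cccs3)cn([C@@H]3O[C@H](CO)[C@@H](O)[C@H]3O)c2n1` gives > 20000 nM, likewise a limit. The step that the two limits leave unreadable from compound 1 to compound 2 is therefore not readable. Compound 2 stands at the limit where two of the three values sit, as seen in the limit of > 20000 nM in this assay, at which 2 of the 3 values shown sit; the remaining value is the limit of > 15000 nM in this assay, at which 1 of the 3 values shown sits. Compound 4 `Nc1nc(N)c2c(-c3ccco3)cn([C@@H]3O[C@H](CO)[C@@H](O)[C@H]3O)c2n1` differs from compound 2 by furan-2-yl in place of furan-3-yl on an aromatic carbon. For the measured compounds named here, no measured step bears on this change, as every value so far is a limit. The expected step that the limit leaves unreadable from compound 2 to compound 4 therefore lies within the scatter. Compound 4 is expected to give 25000 nM, with a range from 8000 nM to 80000 nM.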

Compound 4, half-maximal inhibitory concentration: > 20000 nM
Compound 4 was reported as a limit (the forecaster's own chance of this, stated with the estimate: 85%); the middle value does not contradict the limit.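

In this assay, for the compounds shown here, compound 1, compound 2 and compound 4 are all reported as limits, so no step among them can be read. The compounds shown leave open whether furan-2-yl and furan-3-yl differ at all on the shared core.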